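Lengthening the alkoxy chain on the shared core

The source may report more compounds than this note shows. Statements on the series, on what has been measured and on what is new or still open speak of the compounds shown alone.

Measured compounds:
compound 1, `CC(C(=O)NCc1ccc(C(C)(C)C)cc1N1CCCC1)c1ccc(NS(C)(=O)=O)c(F)c1`, 8.1 nM
compound 2, `CCCOc1cc(C(C)(C)C)ccc1CNC(=O)C(C)c1ccc(NS(C)(=O)=O)c(F)c1`, 4.4 nM
compound 3, `CC(C)COc1cc(C(C)(C)C)ccc1CNC(=O)C(C)c1ccc(NS(C)(=O)=O)c(F)c1`, 2.1 nM

In an assay on cells for antagonist activity at transient receptor potential cation channel subfamily V member 1 (Homo sapiens), read by FLIPR and calcium flux, with a stated time of 6 min (a higher number here means a weaker inhibitor, a lower number a stronger inhibitor), compound 3 gives the lowest of the three numbers; the step of a 2.1-fold lower number from compound 2 to compound 3 (0.32 log units; beyond the scatter) and the step of a 3.9-fold lower number from compound 1 to compound 3 (0.59 log units; beyond the scatter) both lie beyond the scatter, while a 1.8-fold lower number from compound 1 to compound 2 (0.27 log units; within the scatter) does not. Compound 4, `CC(C)CCOc1cc(C(C)(C)C)ccc1CNC(=O)C(C)c1ccc(NS(C)(=O)=O)c(F)c1`, differs from compound 3 by isobutyl in place of isopropyl on a saturated chain carbon bound to an oxygen on an aromatic ring. The nearest comparison is the step of a 2.1-fold lower number from compound 2 to compound 3 (0.32 log units; beyond the scatter), which also grew the chain by one carbon; that step was modest. A further carbon is therefore expected to give at most a small change, as a 1.2-fold lower number from compound 3 to compound 4 (0.07 log units; within the scatter). Compound 4 is thus estimated at 1.8 nM, with a range from 0.7 nM to 5 nM.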

Compound 4, inhibition constant: 0.6 nM
Estimate against measurement, compound 4: 3.0-fold (0.48 log units) above, and the stated range ends above it.
By their numbers in this assay, from the lowest: compound 4; then compound 3; then compounds 2 and 1 (each within the scatter of the next).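

In this assay, lengthening the chain on the oxygen still lowers the number beyond isobutoxy, with isopentyloxy giving a 3.5-fold lower number from compound 3 to compound 4 (0.54 log units; beyond the scatter). Across the propoxy, isobutoxy and isopentyloxy groups, the number falls at each step, adding up to a 7.3-fold lower number from compound 2 to compound 4 (0.87 log units; beyond the scatter), while replacing pyrrolidin-1-yl with isopentyloxy gives a 14-fold lower number from compound 1 to compound 4 (1.13 log units; beyond the scatter), the only step here printed as large. Nothing available explains why the number falls as the chain grows.

Going by these compounds, whether a longer chain, such as hexyloxy, would lower the number further or raise it remains open. So does the outcome of placing an amine or a carboxylic acid at the end of the chain.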